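From Cyclohexyl to Phenyl on a Saturated Chain

The source may report more compounds than this note shows. Statements on the series, on what has been measured and on what is new or still open speak of the compounds shown alone.

Of the compounds shown here, three have been measured in a functional assay on HL-60 cells (Homo sapiens) for antiproliferative activity, read by MTT assay, with a stated time of 72 h; a lower number here means a stronger inhibitor, a higher number a weaker inhibitor. Compound 1 `C/C=C1/[C@H](O[C@@H]2O[C@H](CO)[C@@H](O)[C@H](O)[C@H]2O)OC=C(C(=O)OC)[C@H]1CC(=O)OCCCCCCCCCCCCCCC` gives 380 nM. Compound 2 `C/C=C1/[C@H](O[C@@H]2O[C@H](CO)[C@@H](O)[C@H](O)[C@H]2O)OC=C(C(=O)OC)[C@H]1CC(=O)OCCC1CCCCC1` gives 480 nM, which lies within the scatter of the value for compound 1. Compound 3 `C/C=C1/[C@H](O[C@@H]2O[C@H](COC(C)=O)[C@@H](OC(C)=O)[C@H](OC(C)=O)[C@H]2OC(C)=O)OC=C(C(=O)OC)[C@H]1CC(=O)OCCC` gives 10700 nM, a far higher number than that of compound 2 and well beyond the scatter.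

Compound 4 `C/C=C1/[C@H](O[C@@H]2O[C@H](CO)[C@@H](O)[C@H](O)[C@H]2O)OC=C(C(=O)OC)[C@H]1CC(=O)OCCc1ccccc1` has not yet been measured. It differs from compound 2 by phenyl in place of cyclohexyl on a saturated chain carbon, two bonds along the chain from an oxygen next to a carbonyl group. Among the compounds with values here, no measured pair isolates this kind of change, so the data offer no direct precedent. Compound 1 at 380 nM and compound 2 at 480 nM carry different chain ends, yet their values stay within the scatter. The estimated step of a 1.3-fold higher number from compound 2 to compound 4 (0.10 log units; within the scatter) is therefore expected to be small, towards a higher number, and within the scatter. For compound 4, the expected value in this assay is 600 nM, with an estimated range from 220 nM to 1700 nM.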

Compound 4, half-maximal inhibitory concentration: 10300 nM
The estimate for compound 4 lay 17-fold (1.23 log units) below the measured number; measured number outside the range, above it.
By their numbers in this assay, from the lowest: compounds 1 and 2 (each within the scatter of the next); then compounds 4 and 3 (each within the scatter of the next).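

In this assay, phenyl in place of cyclohexyl on a saturated chain carbon, two bonds along the chain from an oxygen next to a carbonyl group, gives a 21-fold higher number from compound 2 to compound 4 (1.33 log units; beyond the scatter). The earlier compounds shown here held no pair that isolated this change, and it now shows that this place in the chain does not tolerate every six-membered carbon ring alike. The two groups match in heavy atom count and in having no hydrogen-bond donors or acceptors, differing in whether the ring is aromatic, but nothing available explains the size of the step.

This single pair leaves open whether a partly saturated cyclohexenyl ring would fall nearer compound 2 or compound 4. It also leaves open whether a pyridine ring or a longer chain carrying the phenyl would restore the lower number.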